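Exchanging a Benzyl Sulfonamide for a Chlorothiophene Sulfonamide

A few compounds are considered here, and "the series" means these few. Any claim that something is new, unique, unknown or untested is made for them only; others in the source may bear on it.

Measured compounds:
- compound 1, `CC1(C(=O)NS(=O)(=O)Cc2ccc(F)cc2F)CCN(c2nc3c(cc2C#N)C(=O)OC3)CC1`: 8760 nM
- compound 2, `CC1OC(=O)c2cc(C#N)c(N3CCC(C(=O)NS(=O)(=O)Cc4ccccc4)CC3)nc21`: > 300000 nM
- compound 3, `Cc1ccc(CS(=O)(=O)NC(=O)C2CCN(c3nc4c(cc3C#N)C(=O)OC4)CC2)cc1`: 4280 nM

Three compounds sharing a bicyclic lactone-nitrile core linked to an acyl sulfonamide piperidine have been tested in a functional assay (Platelet, plasma) for inhibition, with Homo sapiens as the target; on this read-out lower numbers stand for stronger inhibition and higher numbers for weaker inhibition. Compound 3 gives 4280 nM in this assay, the lowest of the two numbers obtained. Compound 1 gives 8760 nM in this assay, a higher number that lies beyond the scatter of the measurement. For compound 2 this assay reports only a limit, > 300000 nM, as noted in the limit of > 300000 nM in this assay, at which 1 of the 3 values shown sits.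

Compound 4, `N#Cc1cc2c(nc1N1CCC(C(=O)NS(=O)(=O)c3ccc(Cl)s3)CC1)COC2=O`, has not yet been tested. It departs from compound 3 by one change: 5-chlorothiophen-2-yl in place of 4-methylbenzyl on a sulfonyl sulfur. For the measured compounds named here, the step from compound 3 to compound 4 is expected to be modest and towards a lower number, a 2.9-fold lower number from compound 3 to compound 4 (0.46 log units; beyond the scatter) in this assay, though the three measured compounds give no directly comparable precedent for an aryl rather than benzyl substituent on the sulfonyl sulfur. On that basis compound 4 is estimated to give 1500 nM in this assay, with a range from 300 nM to 8000 nM.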

Compound 4, half-maximal inhibitory concentration: 4470 nM
Estimate against measurement, compound 4: 3.0-fold (0.47 log units) below, within the range that was stated.
By their numbers in this assay, from the lowest: compounds 3, 4 and 1 (each within the scatter of the next, the first and the last beyond it). At a limit, above all of these: compound 2.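

In this assay, putting 5-chlorothiophen-2-yl in place of 4-methylbenzyl on a sulfonyl sulfur gives a 1.0-fold higher number from compound 3 to compound 4 (0.02 log units; within the scatter), so the two compounds cannot be told apart on this read-out. The earlier compounds shown here all carried a benzyl group at this place, whereas compound 4 shows that a five-membered aromatic ring with a hetero atom, set directly on the sulfonyl sulfur, reads the same as the 4-methylbenzyl of compound 3. Nothing measured here explains this outcome.

What the chlorine contributes on its own stays open, as the unsubstituted thiophen-2-yl group is not among the compounds shown. As far as these compounds go, it is also open how this place would respond to a group without an aromatic ring, such as a simple alkyl chain, or to a ring bearing an amine or a carboxylic acid.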